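The source may hold more compounds than are shown below. What is called first, only, known or untested is meant among the compounds shown, and "the series" means these compounds.

Measured compounds:
compound 1 `CCC(CC)n1c(-c2ccc(OCc3c(-c4c(Cl)cccc4Cl)noc3C(C)C)cc2F)nc2ccc(C(=O)O)cc21` – 69.3 nM
compound 2 `CCn1c(-c2ccc(OCc3c(-c4c(Cl)cccc4Cl)noc3C(C)C)cc2)nc2ccc(C(=O)O)cc21` – 19.3 nM

In an assay on isolated protein for agonist activity at Bile acid receptor (Homo sapiens), read by TR-FRET (a higher number here means that more compound is needed for the effect, a lower number that less compound is needed), compound 2 gives 19.3 nM, the lower of the two numbers; compound 1 gives 69.3 nM, and the gap between them lies beyond the scatter. Compound 3 `CC(C)c1onc(-c2c(Cl)cccc2Cl)c1COc1ccc(-c2nc3ccc(C(=O)O)cc3n2C2CCCCCC2)cc1` is not yet measured. It differs from compound 2 in one place: cycloheptyl in place of ethyl on an aromatic nitrogen. Going by the values given here, no step between measured compounds isolates this change, so the expected step of a 2.1-fold higher number from compound 2 to compound 3 (0.32 log units; beyond the scatter) in this assay is a modest move toward a higher number, possibly within the scatter. Compound 3 is estimated at 40 nM, between 10 nM and 160 nM.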

Compound 3, half-maximal effective concentration: 113 nM
Compound 3: the middle estimate sits 2.8-fold (0.45 log units) below what was measured; the range from low to high includes it.
By their numbers in this assay, from the lowest: compound 2; then compounds 1 and 3 (each within the scatter of the next).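

Going by these compounds alone, replacing ethyl with cycloheptyl on the aromatic nitrogen gives a 5.9-fold higher number from compound 2 to compound 3 (0.77 log units; beyond the scatter) in this assay and is the first change here isolated to this one position. It shows that the number at this position responds to the group on that nitrogen, with more compound needed once the seven-membered ring replaces the two-carbon group.

From the compounds shown here alone, how cyclopentyl or a straight butyl chain would fall at this nitrogen remains open, as only ethyl and cycloheptyl are compared directly here. Nothing measured here gives a reason for the step.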